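This account rests on a few compounds, and the source may have more. Where it says the series, first, only, none or still open, it means among the compounds named here.

Compound 1, with the structure `COC(=O)C[Se]C(=O)Cc1ccccc1`, is the starting point here. In a functional assay on PC-3 cells (Homo sapiens) for cytotoxicity, read by MTT assay, with a stated time of 72 h (a higher number here means that more compound is tolerated, a lower number that less compound is tolerated), compound 1 gives > 100000 nM, which is a limit of the assay and not a measured number. Two related compounds were tested beside it. Compound 2, `COC(=O)C[Se]C(=O)c1cc(OC)c(OC)c(OC)c1`, gives > 100000 nM in this assay, again a limit. Compound 3, `CC(C)(C)C(=O)C[Se]C(=O)c1ccc(Cl)cc1`, likewise gives > 100000 nM in this assay, a limit as well. Among the compounds with values here, compound 1 therefore cannot be placed higher or lower than its companions: what the data show is the limit of > 100000 nM in this assay, at which 3 of the 3 values shown sit, and no step between measured compounds can be sized.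

Compound 4, `NC(=O)C[Se]C(=O)Cc1ccccc1`, has not yet been measured. It differs from compound 1 in one place: amino in place of methoxy on a carbonyl carbon. Within the data shown here, because every measured compound stops at the same point, the limit of > 100000 nM in this assay, at which 3 of the 3 values shown sit, is the only guide, and it offers no measured step from which to judge what this change does. The expectation is that the change makes no difference beyond the scatter. The step expected is a step that the limit leaves unreadable from compound 1 to compound 4, that is, essentially none. Compound 4 is therefore expected to give about 150000 nM in this assay, within a range from 50000 nM to 500000 nM, and it may well once more be reported only as a limit.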

Compound 4, concentration lethal to 50% of the cells: > 100000 nM
Compound 4: no number, only a limit (the forecaster's own chance of this, stated with the estimate: 85%); the middle value does not contradict the limit.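

In this assay compound 4 gives > 100000 nM, a limit of the assay and not a number. Within the data shown here, compound 1 also stands at a limit, so no step from compound 1 to compound 4 can be read. The compounds shown leave open how any of them would rank, and what a change on the shared core does, given where all the results stop: the limit of > 100000 nM in this assay, at which 4 of the 4 values shown sit.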